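The source may report more compounds than this note shows. Statements on the series, on what has been measured and on what is new or still open speak of the compounds shown alone.

Working notes on the series.

Compound 1 `COc1ccc(CN(C(=O)CSC(=S)N2CCN(C(=O)OC(C)(C)C)CC2)c2ccc(Br)cc2)cc1` and compound 2 `COc1ccc(CN(C(=O)CSC(=S)N2CCN(C(=O)OC(C)(C)C)CC2)c2ccc(C)cc2)cc1` share one core; compound 3 `COc1ccc(CN(C(=O)CSC(=S)N2CCN(C(=O)OC(C)(C)C)CC2)c2cc(OC)c(OC)c(OC)c2)cc1Br` and compound 4 `COc1ccc(CN(C(=O)CSC(=S)N2CCN(C(=O)OC(C)(C)C)CC2)c2cc(OC)c(OC)c(OC)c2)cc1C` share another, and the difference between the two cores is not broken down here. In a functional assay on HCT-116 cells (Homo sapiens) for inhibition, read by CCK-8 assay, with a stated time of 48 h (on this read-out higher numbers stand for weaker inhibition and lower numbers for stronger inhibition), compound 1 reaches only the limit > 20000 nM. In this assay compound 2 likewise reaches only the limit > 20000 nM. The change methyl in place of bromo on an aromatic carbon therefore gives a step that the two limits leave unreadable from compound 1 to compound 2, a step that cannot be read because of the limit of > 20000 nM in this assay, at which 2 of the 3 values shown sit. In this assay compound 3 gives 9710 nM. The change methyl in place of bromo on an aromatic carbon is the same kind of change, though the place differs: in compound 1 the group sits para to a large group, in compound 3 ortho to a methoxy group and meta to a large group. With no readable precedent, the step from compound 3 to compound 4 is expected to be small, a 1.2-fold higher number from compound 3 to compound 4 (0.09 log units; within the scatter). Compound 4 is estimated at 12000 nM, between 5000 nM and 30000 nM.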

Compound 4, half-maximal inhibitory concentration: > 20000 nM
Compound 4: only a limit was reported (the forecaster's own chance of this, stated with the estimate: 35%); middle value at least 1.6-fold (0.22 log units) away from the limit.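

In this assay, on these data alone, methyl in place of bromo in the core of compound 3 gives an at least 2.0-fold higher number from compound 3 to compound 4 (0.31 log units; beyond the scatter), so the loss of inhibition on this change is real in that core, though its full size stays unknown. Compound 4 reaches only the limit > 20000 nM. The same change in the core of compound 1 cannot be read, so the data neither show nor rule out that the step carries from one core to the other: the limit of > 20000 nM in this assay, at which 3 of the 4 values shown sit.

As far as these compounds go, whether an amine or a carboxylic acid in place of the bromo would keep a measurable number in the core of compound 3 stays open. So does the effect of a longer chain at that place.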